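From compound 2 to compound 3: one group exchanged

The compounds below may be only part of what the source reports. "The series", "measured", "known", "first", "only" and "open" are said of these compounds alone.

Compound 1 `Cc1cc(C(=O)O)ccc1OCCCCOc1ccc(C(=O)CC(C)C)c(O)c1C`: 41%
Compound 2 `Cc1c(OCCCCOCOc2ccc(C(=O)O)cc2)ccc(C(=O)CC2CCCC2)c1O`: 31%

In an ADME assay (liver) for metabolic stability, with Liver microsome (Rattus norvegicus) as the target, read by LC-MS, using microsomes and NADPH, with stated times of 5 min and 60 min, tested at 4 uM (a higher number here means that more of the compound is left, a lower number that less of the compound is left), compound 2 gives 31%, which lies within the usual scatter of compound 1 at 41%. Compound 3 `COc1ccc(C(=O)O)cc1OCCCCOc1ccc(C(=O)CC2CCCC2)c(O)c1C` has not yet been measured. Its change is 5-carboxy-2-methoxyphenyl in place of (4-carboxyphenoxy)methyl on an oxygen on a saturated carbon. Going by the values given here, no measured step shows what such an exchange does, so only the closeness of the two known values guides the expectation. The expected result is a number 5 percentage points higher from compound 2 to compound 3 (within the scatter), a slight rise that stays within the scatter. For compound 3 the estimated value is 36%, with an expected range from 18% to 56%.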

Compound 3, percent of the compound remaining: 14%
Compound 3: the middle estimate sits 22 percentage points above what was measured; measured number outside the range, below it.
By their numbers in this assay, from the lowest: compound 3; then compounds 2 and 1 (each within the scatter of the next).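

In this assay, putting 5-carboxy-2-methoxyphenyl in place of (4-carboxyphenoxy)methyl on an oxygen on a saturated carbon gives a number 17 percentage points lower from compound 2 to compound 3 (beyond the scatter), a step beyond the scatter. The two groups hold the same atoms, so rearranging them at this position, with no atoms gained or lost, is enough to change how much compound is left. Nothing measured here explains the change. Still open, from the compounds shown here alone, is which part of the rearrangement matters. Going by these compounds, a group such as an amide or a tetrazole in place of the carboxylic acid remains untested in these compounds.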